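A Nitro Group at a Limit of the Assay

The source may report more compounds than this note shows. Statements on the series, on what has been measured and on what is new or still open speak of the compounds shown alone.

In a functional assay on NCI-H661 cells (Homo sapiens) for inhibition, read by MTT assay, with a stated time of 72 h (a higher number here means a weaker inhibitor, a lower number a stronger inhibitor), compound 1 (`O=C(NO)c1ccc(CNCc2nc(-c3ccc(C(F)(F)F)cc3)no2)cc1`) gives > 100000 nM as a limit of the assay and not a number. Compound 2 (`O=C(NO)c1ccc(CNCc2nc(-c3ccc(Cl)cc3)no2)cc1`) gives > 100000 nM as a limit too, so its place on the scale is known only as a limit. The two compounds share the limit of > 100000 nM in this assay, at which 2 of the 2 values shown sit, and neither has a number yet. Within the data shown here, the one measured step, chloro in place of trifluoromethyl on an aromatic carbon, is a step that the two limits leave unreadable from compound 1 to compound 2 and offers no size to carry forward.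

Compound 3 (`O=C(NO)c1ccc(CNCc2nc(-c3ccc([N+](=O)[O-])cc3)no2)cc1`) departs from compound 2 in a single place: nitro in place of chloro on an aromatic carbon with nitro in place of chloro on an aromatic carbon, para to a large group. The same position has already been changed once, and that change left both compounds as limits. No direction can therefore be named, and no shift beyond the scatter is foreseen in this assay for this new group. The expected size is a number no higher from compound 2 to compound 3 (the limit leaves the size open) on this estimate, and a further limit is the likeliest report. Compound 3 is estimated at 100000 nM with an expected range from 30000 nM to 300000 nM in this assay.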

Compound 3, half-maximal inhibitory concentration: > 100000 nM
Compound 3 was reported as a limit (the forecaster's own chance of this, stated with the estimate: 80%); the middle value lies on the limit itself.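

Compound 3 is reported only as a limit of the assay and not as a number, so no new step can be read among compound 1, compound 2 and compound 3 in this assay: the limit of > 100000 nM in this assay, at which 3 of the 3 values shown sit.

The compounds shown leave open whether any of the trifluoromethyl, chloro and nitro groups differ from one another in this assay, and by how much.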